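The compounds below may be only part of what the source reports. "The series", "measured", "known", "first", "only" and "open" are said of these compounds alone.

Of the compounds shown here, three have been measured in a functional assay on 3T3-L1 cells (Mus musculus) for inhibition, with a stated time of 20 min, tested at 20 uM; a lower number here means less inhibition, a higher number more inhibition at the concentration tested (going by the name of the read-out). Compound 1 `Fc1ccc(CNCc2cccc(F)c2F)cc1` gives -53.4%, compound 2 `Cc1ccc(S(=O)(=O)n2cc(CN(Cc3cccc(F)c3F)C(=O)C(F)(F)F)c3ccccc32)cc1` gives -5.5%, and compound 3 `Cc1ccc(S(=O)(=O)N(Cc2cccc(F)c2F)Cc2cn(S(=O)(=O)c3ccc(C)cc3)c3ccccc23)cc1` gives -13.9%. Compound 3 and compound 2 lie within the scatter of one another, so no order between them can be read, while compound 3 stands well above compound 1, whose number is far lower. Among the compounds with values here, the only measured step, a number 8.4 percentage points lower from compound 2 to compound 3 (within the scatter), swaps one group on the amine nitrogen for another and leaves the read-out essentially unchanged.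

Compound 4 `Cc1ccc(S(=O)(=O)n2cc(CN(Cc3ccccc3)Cc3cccc(F)c3F)c3ccccc32)cc1` is compound 3 with one change: benzyl in place of (4-methylphenyl)sulfonyl on an amine nitrogen. No measured step covers a benzyl at this nitrogen, so the expectation rests on what is shown. The step from compound 2 to compound 3 indicates that changing the group on this nitrogen between two bulky substituents moved little; compound 1, which carries no extra group on its amine nitrogen at all, sits much lower and marks the low end of what has been seen. For compound 4 the step of a number 6.1 percentage points lower from compound 3 to compound 4 (within the scatter) is therefore expected to be small, possibly downward, with wide uncertainty. Compound 4 is estimated at -20%, within a range from -50% to 5%.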

Compound 4, a percentage reported as inhibition, at one concentration (the size of the read-out at that concentration, not a potency): -13.1%
The estimate for compound 4 lay 6.9 percentage points below the measured number; low and high end bracket the measured number.
By their numbers in this assay, from the lowest: compound 1; then compounds 3, 4 and 2 (each within the scatter of the next).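

In this assay, the amine nitrogen of the shared core has now carried three different groups, and the readings stay together: replacing (4-methylphenyl)sulfonyl with benzyl gives a number 0.8 percentage points higher from compound 3 to compound 4 (within the scatter) and replacing (trifluoromethyl)carbonyl with benzyl gives a number 7.6 percentage points lower from compound 2 to compound 4 (within the scatter) on the same nitrogen. What is new is the nature of the entering group: benzyl has 7 heavy atoms, all carbon, and 0 hydrogen-bond acceptors, while (4-methylphenyl)sulfonyl has 10 heavy atoms and 2 hydrogen-bond acceptors, so among these compounds neither a sulfonyl nor a carbonyl on this nitrogen is required for a reading in this range. No independent measurement is available to explain why these groups read alike.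

Going by these compounds, it remains open whether the reading would hold with a very different group on this nitrogen, such as a plain methyl or a longer chain ending in a carboxylic acid or an amine. Compounds 2, 3 and 4 differ only at this nitrogen, so they also leave open how changes elsewhere on the shared core would affect the reading.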